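Replacing an Ester Chain with a Nitrile in a Cytotoxicity Series

The source may report more compounds than this note shows. Statements on the series, on what has been measured and on what is new or still open speak of the compounds shown alone.

Going by the values given here, compound 3 `CCOC(=O)CCn1cc(CNC(=O)c2cnc(Nc3ccc(C#N)cc3)cc2Oc2c(C)cc(C)cc2C)nn1` is the only member of this set for which an ADME assay on MT4 cells (Homo sapiens) for cytotoxicity, read by MTT assay, with a stated time of 5 days (a lower number here means that less compound is tolerated, a higher number that more compound is tolerated), returns an actual number: compound 3 gives 21500 nM. Compound 1 `Cc1cc(C)c(Oc2cc(Nc3ccc(C#N)cc3)ncc2C(=O)NCc2cn(Cc3cccc([N+](=O)[O-])c3)nn2)c(C)c1` reaches only a limit of the assay, giving >= 156000 nM. Compound 2 `Cc1cc(C)c(Oc2cc(Nc3ccc(C#N)cc3)ncc2C(=O)NCc2cn(Cc3ccccc3C#N)nn2)c(C)c1` likewise stops at a limit, giving > 219000 nM. The change from compound 1 to compound 3 gave an at least 7.2-fold lower number from compound 1 to compound 3 (0.86 log units; beyond the scatter), and that from compound 2 to compound 3 gave an at least 10-fold lower number from compound 2 to compound 3 (1.00 log units; beyond the scatter), whereas the step that the two limits leave unreadable from compound 1 to compound 2 cannot be sized.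

Compound 4 `Cc1cc(C)c(Oc2cc(Nc3ccc(C#N)cc3)ncc2C(=O)NCc2cn(CCC#N)nn2)c(C)c1` keeps the shared core and differs from compound 3 by cyano in place of ethoxycarbonyl on a saturated chain carbon, two bonds along the chain from an aromatic nitrogen. Among the compounds with values here, none of the measured steps covers this exchange: the two readable steps both end at compound 3 and put (ethoxycarbonyl)methyl in place of 3-nitrophenyl or 2-cyanophenyl, not cyano in place of ethoxycarbonyl. Within the data shown here, with no direct precedent, the expected step of a 1.4-fold higher number from compound 3 to compound 4 (0.14 log units; within the scatter) in this assay is small, with no direction beyond the scatter. Compound 4 is therefore estimated at 30000 nM, within a range of 8000 nM to 110000 nM.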

Compound 4, half-maximal cytotoxic concentration: 40200 nM
The estimate for compound 4 lay 1.3-fold (0.13 log units) below the measured number; the range from low to high includes it.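

In this assay cyano in place of ethoxycarbonyl, on a saturated chain carbon two bonds along the chain from an aromatic nitrogen, gives a 1.9-fold higher number from compound 3 to compound 4 (0.27 log units; within the scatter) and so the two groups cannot be told apart at this position. Compound 4 carries no ester, yet cyanomethyl in place of 2-cyanophenyl gives an at least 5.4-fold lower number from compound 2 to compound 4 (0.73 log units; beyond the scatter) and cyanomethyl in place of 3-nitrophenyl gives an at least 3.8-fold lower number from compound 1 to compound 4 (0.58 log units; beyond the scatter) so the gap first seen with compound 3 is not tied to ethoxycarbonyl and appears with both short chains. The first of these steps gives only a minimum size, as compound 2 stands at a limit of the assay and not at a true number: the limit of > 219000 nM in this assay, at which 1 of the 4 values shown sits.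

Whether an amine, a carboxylic acid or a longer chain ending in a nitrile at this place would read like compound 3 and compound 4 stays open, as does the reason for the gap itself. The true distance from the short chains to the phenyl-bearing groups is also open, as compound 1 likewise stands at a limit: the limit of >= 156000 nM in this assay, at which 1 of the 4 values shown sits.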